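The source may hold more compounds than are shown below. What is called first, only, known or untested is meant among the compounds shown, and "the series" means these compounds.

Of the compounds shown here, two built on a shared core have so far been measured in a functional assay on A549 cells (Homo sapiens) for antiproliferative activity, read by MTT assay, with a stated time of 72 h; on this read-out lower numbers stand for stronger inhibition and higher numbers for weaker inhibition. Compound 1 `COc1cc2c(Oc3ccc(NC(=O)c4cc(-c5ccc(F)cc5)on4)cc3)ccnc2cc1OCCCN1CCC(C)CC1` gives 3340 nM in this assay, and compound 2 `COc1cc2c(Oc3ccc(NC(=O)c4nc(-c5ccc(F)cc5)no4)cc3)ccnc2cc1OCCCN1CCC(C)CC1` gives 870 nM in this assay. For the measured compounds named here, the single step between them, a 3.8-fold lower number from compound 1 to compound 2 (0.58 log units; beyond the scatter), leaves compound 2 standing with the lowest of the two numbers.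

The next compound, compound 3 `COc1cc2nccc(Oc3ccc(NC(=O)c4nc(-c5ccc(F)cc5)no4)cc3)c2cc1OC`, differs from compound 2 in one place: hydrogen in place of 2-(4-methylpiperidin-1-yl)ethyl on a saturated chain carbon bound to an oxygen on an aromatic ring. Going by the values given here, no measured step touches that part of the molecule; the only step in hand concerns the ring on the carbonyl carbon, and that ring is the same in compound 2 and compound 3. The size of the step from compound 2 to compound 3 in this assay can thus not be read from the numbers shown, and in neither direction is a change beyond the scatter assured. With that caveat, compound 3 is expected to give about 1500 nM in this assay, within a range from 500 nM to 5000 nM. That estimate corresponds to an expected step of a 1.7-fold higher number from compound 2 to compound 3 (0.24 log units; within the scatter), a shift of modest size at most.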

Compound 3, half-maximal inhibitory concentration: 10300 nM
Estimate against measurement, compound 3: 6.9-fold (0.84 log units) below, outside the stated range (above it).
By their numbers in this assay, from the lowest: compound 2; then compound 1; then compound 3.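

In this assay, cutting 3-(4-methylpiperidin-1-yl)propoxy back to methoxy, with the ring on the carbonyl carbon left unchanged, gives a 12-fold higher number from compound 2 to compound 3 (1.07 log units; beyond the scatter). For the compounds shown here, this is the first view of this position, and it shows that the read-out depends strongly on what is carried there: the step is large, while the only earlier step, at the ring on the carbonyl carbon, was modest. Nothing available bears on why the number rises with this change.

The compounds shown give only the two extremes at this position, so it remains open whether the step follows the amine, the piperidine ring or the chain itself; a morpholine or a dimethylamine at the end of the same chain, a plain propoxy group without an amine, or a longer chain would help separate these. From the compounds shown here alone, it is also open whether the step would keep its size with 5-(4-fluorophenyl)-1,2-oxazol-3-yl on the carbonyl carbon, as methoxy appears here only with the other ring.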